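A Methoxymethoxy Group Replaces Amino on the Shared Core

The compounds below may be only part of what the source reports. "The series", "measured", "known", "first", "only" and "open" are said of these compounds alone.

Measured so far:
compound 1 `O=C(/C=C/c1ccc2c(c1)B(O)OC2)c1ccccc1`: 6100 nM
compound 2 `Nc1cccc(C(=O)/C=C/c2ccc3c(c2)B(O)OC3)c1`: 4500 nM

Among the compounds with values here, in a functional assay on HCT-116 cells (Homo sapiens) for cytotoxicity, read by MTT assay, with a stated time of 48 h (a higher number here means a weaker inhibitor, a lower number a stronger inhibitor), compound 2 gives 4500 nM and compound 1 gives 6100 nM; the only measured step, a 1.4-fold lower number from compound 1 to compound 2 (0.13 log units; within the scatter), lies within the scatter, so the two compounds cannot be told apart on these numbers. Compound 3 `COCOc1cccc(C(=O)/C=C/c2ccc3c(c2)B(O)OC3)c1` differs from compound 2 by methoxymethoxy in place of amino on an aromatic carbon. Within the data shown here, no measured step involves methoxymethoxy, and the one step at this position was within the scatter, so no change beyond the scatter is expected. Compound 3 is therefore estimated at 5000 nM, between 2000 nM and 12000 nM, which means an expected 1.1-fold higher number from compound 2 to compound 3 (0.05 log units; within the scatter).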

Compound 3, half-maximal inhibitory concentration: 13300 nM
The estimate for compound 3 lay 2.7-fold (0.42 log units) below the measured number, and the stated range ends below it.
By their numbers in this assay, from the lowest: compounds 2 and 1 (each within the scatter of the next); then compound 3.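

In this assay this position proves able to shift the number: methoxymethoxy in place of amino gives a 3.0-fold higher number from compound 2 to compound 3 (0.47 log units; beyond the scatter) and methoxymethoxy in place of hydrogen gives a 2.2-fold higher number from compound 1 to compound 3 (0.34 log units; beyond the scatter) and both steps are modest but beyond the scatter. Amino and hydrogen could not be told apart, so methoxymethoxy is the first group here to separate from the others, in the direction of a weaker inhibitor. No evidence on hand accounts for this difference.

On these data alone, whether a plain methoxy, a hydroxyl or a carboxylic acid at this position would also raise the number stays open. So does whether a longer ether chain would raise it further.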